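From 3,4-dimethoxyphenyl to 3-fluorophenyl on compound 1

The compounds below may be only part of what the source reports. "The series", "measured", "known", "first", "only" and "open" are said of these compounds alone.

Measured in a functional assay on A549 cells (Homo sapiens) for cytotoxicity, read by MTT assay, with a stated time of 72 h; a higher number here means a weaker inhibitor, a lower number a stronger inhibitor:
compound 1 `COc1ccc(NC(=O)CN2CCN(c3nnc(Cc4ccncc4)c4ccccc34)CC2)cc1OC`: 26500 nM
compound 2 `O=C(CN1CCN(c2nnc(Cc3ccncc3)c3ccccc23)CC1)Nc1ccc(Br)cc1`: 2710 nM
compound 3 `O=C(CN1CCN(c2nnc(Cc3ccccc3)c3ccccc23)CC1)Nc1ccc(F)c(C(F)(F)F)c1`: 2480 nM

Compound 1 has the highest number of these three, which makes it the weakest inhibitor among them. Compound 4 `O=C(CN1CCN(c2nnc(Cc3ccncc3)c3ccccc23)CC1)Nc1cccc(F)c1` has not yet been measured. It keeps the core of compound 1 and exchanges one group: 3-fluorophenyl in place of 3,4-dimethoxyphenyl on an amide-type nitrogen. In words, 3-fluorophenyl stands in place of 3,4-dimethoxyphenyl on an amide-type nitrogen.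

Within the data shown here, the closest precedent exchanges the same group for 4-bromophenyl: a 9.8-fold lower number from compound 1 to compound 2 (0.99 log units; beyond the scatter). That drop lies beyond the scatter. Compound 3 also sits well under compound 1, but it differs in more than one place, so it offers only loose support. One step cannot show how 3-fluorophenyl will compare with 4-bromophenyl, so a drop in this assay is expected, possibly a smaller one. The estimated change is a 5.3-fold lower number from compound 1 to compound 4 (0.72 log units; beyond the scatter). Compound 4 is expected at 5000 nM, with an estimated range of 1800 nM to 14000 nM.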

Compound 4, half-maximal inhibitory concentration: 4600 nM
Compound 4: the middle estimate sits 1.1-fold (0.04 log units) above what was measured; the range from low to high includes it.
By their numbers in this assay, from the lowest: compounds 3, 2 and 4 (each within the scatter of the next); then compound 1.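

In this assay, a second replacement of the 3,4-dimethoxyphenyl on the amide-type nitrogen also lowers the number (a 5.8-fold lower number from compound 1 to compound 4 (0.76 log units; beyond the scatter)), so the drop seen with 4-bromophenyl is no longer a single case. The two halogen-bearing groups cannot be told apart here (a 1.7-fold higher number from compound 2 to compound 4 (0.23 log units; within the scatter)), even though they carry different halogens at different ring positions. No measurement shown here explains why compound 1 has the highest number of this set.

The compounds shown leave open whether the drop comes from losing the two methoxy groups or from gaining a halogen, a question that a plain phenyl or a 3-methoxyphenyl on the same nitrogen could help to settle. They also leave open how an amine or a carboxylic acid on that ring would behave.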